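Compound 3 to compound 4: hydrogen for fluoro

The compounds below may be only part of what the source reports. "The series", "measured", "known", "first", "only" and "open" are said of these compounds alone.

In an ADME assay on BJ cells (Homo sapiens) for cytotoxicity, with a stated time of 72 h (on this read-out lower numbers stand for an effect already at smaller amounts and higher numbers for an effect only at larger amounts of compound), every result so far is a limit rather than a number. Compound 1 (`COc1cccc(-c2nc3c(c(C)nn3-c3ccccc3)c(-c3ccccc3O)c2C#N)c1`) gives the limit > 23000 nM. Compound 2 (`Cc1nn(-c2ccccc2)c2nc(-c3ccccc3)c(C#N)c(-c3ccccc3O)c12`) gives the limit > 23000 nM. Compound 3 (`CCc1ccc(-c2nc3c(c(C)nn3-c3ccccc3)c(-c3ccccc3F)c2C#N)cc1`) gives the limit > 20000 nM, so it has no readable number either.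

Compound 4 (`CCc1ccc(-c2nc3c(c(C)nn3-c3ccccc3)c(-c3ccccc3)c2C#N)cc1`) has hydrogen in place of fluoro on an aromatic carbon, ortho to a large group: hydrogen in place of fluoro on an aromatic carbon. Among the compounds with values here, the only measured step, a step that the two limits leave unreadable from compound 1 to compound 2, also puts hydrogen on an aromatic carbon, though in place of methoxy, and gives no size.

No step beyond the scatter is expected in either direction, and the estimated step is a step that the limit leaves unreadable from compound 3 to compound 4. For compound 4 the expected value is 25000 nM, with an estimated range of 12000 nM to 50000 nM.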

Compound 4, half-maximal effective concentration: > 20000 nM
Compound 4: a limit, no number; the forecaster's own chance of this, stated with the estimate: 85%; the middle value is on the limit's open side.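

Compound 3 and compound 4 are both limits, so no step can be read between them. The compounds shown leave open whether exchanging fluoro for hydrogen changes the result in this assay, as none of them gives a number.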